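Cyclobutyl in place of cyclobutylmethyl on a sulfonamide nitrogen

The compounds below may be only part of what the source reports. "The series", "measured", "known", "first", "only" and "open" are said of these compounds alone.

- compound 1 `CCc1ccc(N(CC2CCC2)S(=O)(=O)c2ccc3c(c2)C(=O)CC(C2CCOCC2)O3)cc1` gives 4.1
- compound 2 `CCc1ccc(N(CC(C)C)S(=O)(=O)c2ccc3c(c2)C(=O)CC(C2CCN(C(=O)OC(C)(C)C)CC2)O3)cc1` gives 5.1
- compound 3 `CCc1ccc(N(CC(C)C)S(=O)(=O)c2ccc3c(c2)C(=O)C[C@H](C2CCOCC2)O3)cc1` gives 4.24

In a physicochemical assay for lipophilicity, at pH 7.4 (a lower number here means a more polar compound, a higher number a more lipophilic compound), compound 1 and compound 3 lie within the usual scatter of each other, and compound 2 stands higher, beyond that scatter. Compound 4 `CCc1ccc(N(C2CCC2)S(=O)(=O)c2ccc3c(c2)C(=O)CC(C2CCOCC2)O3)cc1` keeps the core of compound 1 and carries cyclobutyl in place of cyclobutylmethyl on a sulfonamide nitrogen. Within the data shown here, no measured pair shows this change, so the expectation rests on the structural change alone: a small downward step in this assay, near the edge of the scatter. The estimated change is a number 0.35 log units lower from compound 1 to compound 4 (beyond the scatter). Compound 4 is expected at 3.75, with an estimated range from 3.35 to 4.15.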

Compound 4, distribution coefficient: 3.78
The estimate for compound 4 lay 0.03 log units below the measured number, within the range that was stated.
By their numbers in this assay, from the lowest: compound 4; then compounds 1 and 3 (each within the scatter of the next); then compound 2.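

In this assay, cyclobutyl in place of cyclobutylmethyl on the sulfonamide nitrogen gives a number 0.32 log units lower from compound 1 to compound 4 (beyond the scatter), a modest step. Among these compounds, this is the first pair here that differs in one place only, so it shows that this substituent alone can shift the number, even with the four-membered ring present on both sides. Nothing measured here gives a reason for the shift.

Going by these compounds, whether the step carries over to the other compounds stays open. So does the effect of a cyclopentyl ring, or of a longer chain ending in an amine or a carboxylic acid, on this nitrogen.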